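Compound 3 to compound 4: a methyl step

This account rests on a few compounds, and the source may have more. Where it says the series, first, only, none or still open, it means among the compounds named here.

In an ADME assay on LLC-PK1 cells (Sus scrofa) for permeability (on this read-out lower numbers stand for lower permeability and higher numbers for higher permeability), compound 1 `COC[C@]12C[C@H]1[C@@](C)(c1cc(NC(=O)c3ccc(Cl)cn3)cc(F)c1F)N=C(N)S2` gives 13 10^-6 cm/s, compound 2 `COC[C@]12C[C@H]1[C@@](C)(c1cc(NC(=O)c3ccc(OCC(F)(F)F)cn3)cc(F)c1F)N=C(N)S2` gives 18 10^-6 cm/s and compound 3 `C#CCOc1ccc(C(=O)Nc2cc(F)c(F)c([C@@]3(C)N=C(N)S[C@@]4(COC)C[C@H]43)c2)nc1` gives 14 10^-6 cm/s. On these numbers compound 3 cannot be separated from either of the other two. Compound 4 `C#CCOc1cnc(C(=O)Nc2cc(F)c(F)c([C@@]3(C)N=C(N)S[C@@]4(COC)C[C@H]43)c2)c(C)c1` has methyl in place of hydrogen on an aromatic carbon, ortho to a large group: methyl in place of hydrogen on an aromatic carbon. Among the compounds with values here, no measured compound carries this methyl, so the evidence is indirect. The measured steps exchange other groups: a 1.4-fold higher number from compound 1 to compound 2 (0.14 log units; within the scatter), a 1.1-fold higher number from compound 1 to compound 3 (0.03 log units; within the scatter) and a 1.3-fold lower number from compound 2 to compound 3 (0.11 log units; within the scatter). Going by these, no change beyond the scatter is expected in this assay. The expected step is a 1.1-fold higher number from compound 3 to compound 4 (0.03 log units; within the scatter). For compound 4 the estimate is 15 10^-6 cm/s, with an expected range of 9 10^-6 cm/s to 25 10^-6 cm/s.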

Compound 4, apparent permeability: 19 10^-6 cm/s
Compound 4: the middle estimate sits 1.3-fold (0.10 log units) below what was measured; the range from low to high includes it.
By their numbers in this assay, from the lowest: compounds 1, 3, 2 and 4 (each within the scatter of the next).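

In this assay, methyl in place of hydrogen, on an aromatic carbon ortho to a large group and two atoms from the ring nitrogen, gives a 1.4-fold higher number from compound 3 to compound 4 (0.13 log units; within the scatter), so this position takes the added methyl with no step beyond the scatter. The full exchange of 5-chloropyridin-2-yl for 3-methyl-5-(propargyloxy)pyridin-2-yl gives a 1.5-fold higher number from compound 1 to compound 4 (0.16 log units; within the scatter), which also stays within the scatter. No measurement on hand bears on the cause of either step.

Going by these compounds, whether an amine or a carboxylic acid at this position would give a step beyond the scatter remains open. So does whether the methyl gives the same step with chloro in place of propargyloxy.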